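Imidazole chain analogues: from branched ester to dimethylamide

This account rests on a few compounds, and the source may have more. Where it says the series, first, only, none or still open, it means among the compounds named here.

Compound 1 `COC(=O)COc1cccc(-n2cnc(-c3ccccc3)c2-c2ccccc2)c1`; in an assay on H4 cells for inhibition of Fatty-acid amide hydrolase 1 (Homo sapiens) (a lower number here means a stronger inhibitor, a higher number a weaker inhibitor), compound 1 gives 6500 nM.
Compound 2 `CCc1nc(-c2ccccc2)c(-c2ccccc2)n1CCCCCCCC(=O)OC`; in this assay compound 2 gives 31 nM.
Compound 3 `CCOC(=O)CC(CC)CCCCCn1c(C)nc(-c2ccccc2)c1-c1ccccc1`; in this assay compound 3 gives 9900 nM.

Among these three, compound 3 carries the highest number in this assay. Its nearest neighbour is compound 1, whose number lies within the usual scatter of it, while compound 2 sits far below, well beyond the scatter. Compound 4 `Cc1nc(-c2ccccc2)c(-c2ccccc2)n1CCCCCCC(=O)N(C)C` is not yet measured. It differs from compound 3 by (dimethylcarbamoyl)methyl in place of 1-((ethoxycarbonyl)methyl)propyl on a saturated chain carbon, five bonds along the chain from an aromatic nitrogen. For the measured compounds named here, no measured pair tells this step directly. The unbranched chain of compound 4 resembles that of compound 2 more than the branched chain of compound 3, so the step is expected to fall toward a lower number, beyond the scatter: a 33-fold lower number from compound 3 to compound 4 (1.52 log units; beyond the scatter). For compound 4 the estimate in this assay is 300 nM, expected between 50 nM and 2000 nM.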

Compound 4, half-maximal inhibitory concentration: 970 nM
Compound 4: middle estimate off by 3.2-fold (0.51 log units), on the low side; the range from low to high includes it.
By their numbers in this assay, from the lowest: compound 2; then compound 4; then compounds 1 and 3 (each within the scatter of the next).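

In this assay this position proves sensitive to the chain end: replacing 1-((ethoxycarbonyl)methyl)propyl with (dimethylcarbamoyl)methyl gives a 10-fold lower number from compound 3 to compound 4 (1.01 log units; beyond the scatter). For the compounds shown here, the earlier compounds offered no single-place step, so this is the first direct reading of a change here. No measurement at hand accounts for the shift.

On these data alone, the branch and the ethoxycarbonyl group leave together, so their separate shares stay open. As far as these compounds go, how a carboxylic acid or a primary amide at the chain end would read in this assay also remains open.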